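The compounds below may be only part of what the source reports. "The series", "measured", "known", "first", "only" and "open" are said of these compounds alone.

Compound 1 (`C=CC1=C(C(=O)NCCC)C(c2ccc(Cl)c(Cl)c2)OC1`) carries a propylcarbamoyl group on its core. In a functional assay on SW480 cells (Homo sapiens) for cytotoxicity, read by MTT assay, with a stated time of 24 h (a higher number here means a weaker inhibitor, a lower number a stronger inhibitor), compound 1 gives > 100000 nM, which is a limit of the assay and not a number. Compound 2 (`C=CC1=C(C(=O)NCc2ccc(Cl)cc2)C(c2ccc(OC)c(OC)c2)OC1`), built on the same core, stands no differently. In this assay compound 2 gives > 100000 nM, again a limit rather than a number. Compound 1 therefore cannot be ranked against anything shown: the limit of > 100000 nM in this assay, at which 2 of the 2 values shown sit, and no step between measured compounds can be drawn. Compound 3 (`C=CC1=C(C(=O)O)C(c2ccc(Cl)c(Cl)c2)OC1`) is the carboxy counterpart of compound 1; the change is hydroxy in place of propylamino on a carbonyl carbon. Among the compounds with values here, no compound with a measured number is available to anchor this change. The step that the limit leaves unreadable from compound 1 to compound 3 is expected to stay within the scatter, with no direction beyond it. Compound 3 is expected at 200000 nM, between 60000 nM and 1000000 nM, most likely once more reported as a limit.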

Compound 3, half-maximal inhibitory concentration: > 100000 nM
Compound 3 was reported as a limit; the forecaster's own chance of this, stated with the estimate: 85%; the middle value is on the limit's open side.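

No step from compound 1 to compound 3 can be read, as both are reported only as a limit of the assay and not as a number: the limit of > 100000 nM in this assay, at which 3 of the 3 values shown sit.

Going by these compounds, what propylcarbamoyl to carboxy does in this assay stays open, as does how any compound on the shared core would rank there.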